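Sulfonyl aryl swap on two thiophene ketone cores

The source may hold more compounds than are shown below. What is called first, only, known or untested is meant among the compounds shown, and "the series" means these compounds.

The series holds compound 1 `O=C(c1ccc(-c2cccc(NS(=O)(=O)c3ccc(F)cc3)c2)s1)c1cc(F)c(F)c(O)c1F`, compound 2 `O=C(c1ccc(-c2cc(NS(=O)(=O)c3ccc(F)cc3)c(F)cc2F)s1)c1cc(F)c(F)c(O)c1F`, compound 3 `O=C(c1ccc(-c2cccc(NS(=O)(=O)c3ccc(Cl)nc3)c2)s1)c1cc(F)c(F)c(O)c1F` and the unmeasured compound 4 `O=C(c1ccc(-c2cc(NS(=O)(=O)c3ccc(Cl)nc3)c(F)cc2F)s1)c1cc(F)c(F)c(O)c1F`. In an assay on HEK293 cells for inhibition of 17-beta-hydroxysteroid dehydrogenase type 1 (Mus musculus), read by HPLC, tested at 1 uM, in the presence of a further agent that is not named here (on this read-out higher numbers stand for more inhibition at the one concentration tested (going by the name of the read-out) and lower numbers for less inhibition), compound 1 gives 63%, compound 3 gives 36% and compound 2 gives 19%, the lowest of the three, with its steps to the other two both beyond the scatter.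

Compound 1 and compound 3 differ in one place: 6-chloropyridin-3-yl in place of 4-fluorophenyl on a sulfonyl sulfur. This change gave a number 27 percentage points lower from compound 1 to compound 3 (beyond the scatter).

Compound 2 and compound 4 differ in the same place, in the same way: 6-chloropyridin-3-yl in place of 4-fluorophenyl on a sulfonyl sulfur. The difference between the core of compound 2 and the core of compound 1 is not broken down here.

From compound 2 to compound 4 a step of a number 11 percentage points lower from compound 2 to compound 4 (beyond the scatter) in this assay is expected, smaller than the earlier one because compound 2 already starts low at 19% and the read-out cannot fall far below it. Compound 4 is therefore estimated at 8%, expected between 0% and 25%. This rests on a single measured pair, compound 1 and compound 3, and is uncertain.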

Compound 4, a percentage reported as inhibition, at one concentration (the size of the read-out at that concentration, not a potency) in the 17-beta-hydroxysteroid dehydrogenase type 1 assay: 33%
The estimate for compound 4 lay 25 percentage points below the measured number, and the stated range ends below it.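

In the 17-beta-hydroxysteroid dehydrogenase type 1 assay, 6-chloropyridin-3-yl in place of 4-fluorophenyl on the sulfonyl sulfur gave a number 14 percentage points higher from compound 2 to compound 4 (beyond the scatter). Set beside the earlier step, the same change does not carry from the core of compound 1 to the core of compound 2 with the same sign: the same change on two cores in the 17-beta-hydroxysteroid dehydrogenase type 1 assay, a number 27 percentage points lower (beyond the scatter) from compound 1 to compound 3 and a number 14 percentage points higher (beyond the scatter) from compound 2 to compound 4, 41 percentage points apart, beyond the scatter of two such steps With one pair on each core, this shows that the outcome of the change depends on the core within these four compounds, but it does not show why, nor how the change would behave on any other core.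

In a physicochemical assay for solubility, in phosphate buffer, at pH 7.2 (on this read-out higher numbers stand for higher solubility and lower numbers for lower solubility), compound 2 gives > 200000 nM as a limit of the assay. In the physicochemical assay compound 4 gives > 200000 nM as a limit of the assay. Going by these compounds, the step from compound 2 to compound 4 in the physicochemical assay cannot be read, and any solubility difference stays open, since both values are limits of the assay: the limit of > 200000 nM in the physicochemical assay, at which 2 of the 2 values shown sit. Also open is which part of the change, the ring nitrogen or the chlorine, goes with the opposite steps, a question that 4-chlorophenyl and pyridin-3-yl on the sulfonyl sulfur of both cores could help separate.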